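Swapping the phenyl group on the shared core

The source may report more compounds than this note shows. Statements on the series, on what has been measured and on what is new or still open speak of the compounds shown alone.

compound 1 `COc1cccc(CNc2nc(Nc3ccc(N4CCN(C)CC4)cn3)ncc2Cl)c1`: 73400 nM
compound 2 `Cc1cccc(Nc2nc(Nc3ccc(N4CCN(C)CC4)cn3)ncc2Cl)c1`: 15300 nM
compound 3 `CC(C)c1cccc(Nc2nc(Nc3ccc(N4CCN(C)CC4)cn3)ncc2Cl)c1`: 12300 nM

These numbers come from a functional assay on Jurkat cells (Homo sapiens) for inhibition, read by CCK-8 assay, with a stated time of 48 h; a lower number here means a stronger inhibitor of growth, a higher number a weaker inhibitor of growth. Exchanging methyl for isopropyl on the phenyl ring gives a 1.2-fold lower number from compound 2 to compound 3 (0.09 log units; within the scatter), so these two compounds stand level. Both lie clearly under the number of the benzyl compound, as a 4.8-fold lower number from compound 1 to compound 2 (0.68 log units; beyond the scatter) and a 6.0-fold lower number from compound 1 to compound 3 (0.78 log units; beyond the scatter) show.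

The next compound, compound 4 `COc1ccc(Nc2nc(Nc3ccc(N4CCN(C)CC4)cn3)ncc2Cl)cc1`, keeps the shared core and carries 4-methoxyphenyl in place of 3-isopropylphenyl on a nitrogen on an aromatic ring. Among the measured compounds shown here, no measured compound carries this group, so there is no direct test of it. The two larger steps replace 3-methoxybenzyl, a group absent from both compound 3 and compound 4, so they bear on this change only weakly. The closest guide is the small step between the two phenyl compounds, a 1.2-fold lower number from compound 2 to compound 3 (0.09 log units; within the scatter). On that basis, no shift beyond the scatter is expected in this assay, although the range must stay wide. The expected step is a 1.1-fold higher number from compound 3 to compound 4 (0.06 log units; within the scatter). Compound 4 is estimated at 14000 nM, with an expected range from 5500 nM to 36000 nM.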

Compound 4, concentration for 50% growth inhibition: 11200 nM
Compound 4: the middle estimate sits 1.3-fold (0.10 log units) above what was measured; low and high end bracket the measured number.
By their numbers in this assay, from the lowest: compounds 4, 3 and 2 (each within the scatter of the next); then compound 1.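

In this assay, 4-methoxyphenyl on the nitrogen stands level with both 3-isopropylphenyl and 3-methylphenyl, as a 1.1-fold lower number from compound 3 to compound 4 (0.04 log units; within the scatter) and a 1.4-fold lower number from compound 2 to compound 4 (0.14 log units; within the scatter) show. This change alters two things at once, bringing in an oxygen and a hydrogen-bond acceptor and also moving the substituent to a different numbered place on the phenyl ring, yet the result stays within the scatter, so the number is not sensitive to this combined change. Compound 4 also falls clearly under the benzyl compound, with a 6.6-fold lower number from compound 1 to compound 4 (0.82 log units; beyond the scatter), so all three compounds with a phenyl group directly on the nitrogen now stand apart from compound 1.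

No available data explain these steps, and the two parts of the change cannot be told apart, since their separate effects could be small or could offset each other. A 3-methoxyphenyl group would separate the place of the methoxy group from its presence, while a phenyl ring carrying an amine or a carboxylic acid would test whether this level holds for quite different substituents.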